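The compounds below may be only part of what the source reports. "The series", "measured", "known", "first", "only" and "open" are said of these compounds alone.

Measured so far:
- compound 1 `Cc1cn([C@H]2C[C@H](N=[N+]=[N-])[C@@H](COP(=O)(O)Oc3ccccc3)O2)c(=O)[nH]c1=O`: 9.47 h
- compound 2 `O=c1ccn([C@H]2CC[C@@H](COP(=O)(O)Oc3cccnc3)O2)c(=O)[nH]1`: 50.2 h
- compound 3 `Nc1ncnc2c1ncn2[C@H]1CC[C@@H](COP(=O)(O)Oc2cccnc2)O1`: 64.2 h

In a physicochemical assay for metabolic stability, read by HPLC (a lower number here means that the compound disappears faster, a higher number that the compound lasts longer), compound 1 gives 9.47 h, the lowest of the three numbers. Compound 2 stands a good deal higher at 50.2 h, and compound 3 higher still at 64.2 h; both gaps to compound 1 lie beyond the scatter, while the two higher compounds share a different sugar and a pyridinyl ester and so are not single-change neighbours of compound 1.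

The step in question leads from compound 1 to compound 4 `Cc1cn([C@H]2C[C@H](N=[N+]=[N-])[C@@H](COP(=O)(O)Oc3ccc(C#N)cc3)O2)c(=O)[nH]c1=O`, which has not yet been measured in this assay. The change is cyano in place of hydrogen on an aromatic carbon. Within the data shown here, no measured pair shows this change, so the expectation rests on compound 1 alone. A moderate drop is expected, a 2.1-fold lower number from compound 1 to compound 4 (0.32 log units; beyond the scatter), taken as the most likely direction without a measured precedent. Compound 4 is therefore estimated at 4.5 h, with a range from 1.5 h to 12 h.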

Compound 4, half-life: 7.08 h
Estimate against measurement, compound 4: 1.6-fold (0.20 log units) below, and the stated range covers the measured number.
By their numbers in this assay, from the lowest: compounds 4 and 1 (each within the scatter of the next); then compounds 2 and 3 (each within the scatter of the next).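

In this assay, cyano in place of hydrogen on an aromatic carbon, para to a large group, gives a 1.3-fold lower number from compound 1 to compound 4 (0.13 log units; within the scatter). Among these compounds, this is the first step in the set that changes a single place, and it shows that on the core of compound 1, going from phenoxy to 4-cyanophenoxy leaves the half-life indistinguishable from that of the parent within the usual scatter. Nothing shown accounts for this result, so it stands as an observation without an explanation.

From the compounds shown here alone, it remains open whether a different group at the same place, such as an amine, a carboxylic acid or a methoxy group, would also leave the half-life unchanged. Going by these compounds, it is equally open whether cyano would behave the same way on the esters of compound 2 and compound 3, which differ from compound 1 in more than one place.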